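Trifluoromethyl in place of methylsulfonyl on compound 3

A few compounds are considered here, and "the series" means these few. Any claim that something is new, unique, unknown or untested is made for them only; others in the source may bear on it.

The three measured compounds and their readings in a functional assay on MCF7 cells (Homo sapiens) for cytotoxicity, read by CellTiter-Glo, with a stated time of 5 days (a lower number here means a stronger inhibitor, a higher number a weaker inhibitor), are:
compound 1 `CC/C(=C(/c1ccc(/C=C/C(=O)O)cc1)c1ccc2[nH]ncc2c1OC)c1ccccc1` gives 55 nM
compound 2 `O=C(O)/C=C/c1ccc(/C(=C(\c2ccc(F)cc2Cl)C2CCC2)c2ccc3[nH]nc(F)c3c2)cc1` gives 2 nM
compound 3 `CS(=O)(=O)c1ccc(/C(=C(\c2ccc(/C=C/C(=O)O)cc2)c2ccc3[nH]nc(F)c3c2)C2CCC2)c(Cl)c1` gives 2.3 nM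

Compound 3 stands together with compound 2 at the low end of these three numbers; the two lie within the scatter of each other, while compound 1 gives a reading far above both. For the measured compounds named here, the one step measured at the position in question, a 1.2-fold higher number from compound 2 to compound 3 (0.06 log units; within the scatter), shows that putting methylsulfonyl where fluoro had been left the reading essentially where it was.

Compound 4 `O=C(O)/C=C/c1ccc(/C(=C(\c2ccc(C(F)(F)F)cc2Cl)C2CCC2)c2ccc3[nH]nc(F)c3c2)cc1` is the next variation on this shared core. Its difference from compound 3 is trifluoromethyl in place of methylsulfonyl on an aromatic carbon. Going by the values given here, only the step of a 1.2-fold higher number from compound 2 to compound 3 (0.06 log units; within the scatter) bears on this position, and it was within the scatter. Since groups as unlike as fluoro and methylsulfonyl returned the same reading there, a trifluoromethyl group is expected to do the same, with no step beyond the scatter in this assay. The step expected in this assay is a 1.1-fold higher number from compound 3 to compound 4 (0.04 log units; within the scatter). Compound 4 is accordingly estimated at 2.5 nM, with a range from 1 nM to 6.5 nM.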

Compound 4, half-maximal inhibitory concentration: 8.2 nM
Compound 4: the middle estimate sits 3.3-fold (0.52 log units) below what was measured; measured number above the stated range.
By their numbers in this assay, from the lowest: compounds 2 and 3 (each within the scatter of the next); then compound 4; then compound 1.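

In this assay the place para to a large group turns out not to accept every substituent alike, since trifluoromethyl gives a 3.6-fold higher number from compound 3 to compound 4 (0.55 log units; beyond the scatter) and likewise a 4.1-fold higher number from compound 2 to compound 4 (0.61 log units; beyond the scatter) on the same core. The earlier step, a 1.2-fold higher number from compound 2 to compound 3 (0.06 log units; within the scatter) with methylsulfonyl replacing fluoro, had shown only that these two groups read alike, and it now stands as a match between those two groups rather than as a sign that the position is indifferent to change. Of the three groups measured here, trifluoromethyl alone stands apart, though only by a modest step, and nothing in the data explains why this group departs from the other two.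

What the compounds shown leave open is how a nitrile, a methoxy group, an amine or a carboxylic acid on this aromatic carbon would read, and so whether fluoro and methylsulfonyl or trifluoromethyl is the exception. Going by these compounds, all three compounds also keep the chloro group on this ring, so whether the step from methylsulfonyl to trifluoromethyl persists with hydrogen or methyl in its place remains open.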